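Notes on one open step in a small series

A few compounds are considered here, and "the series" means these few. Any claim that something is new, unique, unknown or untested is made for them only; others in the source may bear on it.

Measured so far:
compound 1 `COc1cc(OC)c(OC)cc1/C=C/COC(=O)/C=C/c1cc(OC)c(OC)c(OC)c1OC` gives 42.2 mg/kg
compound 2 `COc1cc(OC)c(OC)cc1/C=C/COC(=O)/C=C/c1ccccc1C(F)(F)F` gives 123 mg/kg

Both values come from a functional assay on the whole organism (strain Kunming) with Mus musculus as the target, in the formalin test, with a stated time of 0.5 h (a higher number here means that more compound is needed for the effect, a lower number that less compound is needed), and they sit apart beyond the scatter. Compound 2 stands highest of the two, and compound 1 is its nearest neighbour with the lower number. The open structure is compound 3 `COc1cc(OC)c(OC)cc1/C=C/COC(=O)/C=C/c1ccc(Cl)cc1` and it differs from compound 2 in one place, on a double-bonded chain carbon bound to a double-bonded chain carbon, with 4-chlorophenyl in place of 2-(trifluoromethyl)phenyl on a double-bonded chain carbon bound to a double-bonded chain carbon as the counted change. Within the data shown here, no measured step covers such a change. Among the measured compounds shown here, the only guide is the spread of the two values, and compound 2 at 123 mg/kg sits at its top end. A small downward move within the scatter is expected, though the opposite direction cannot be ruled out. The expected change is a 1.5-fold lower number from compound 2 to compound 3 (0.19 log units; within the scatter) in this estimate. For compound 3 the estimated value is 80 mg/kg with an expected range from 35 mg/kg up to 170 mg/kg for now.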

Compound 3, dose for half-maximal effect: 108 mg/kg
For compound 3 the middle estimate is 1.4-fold (0.13 log units) below the measured one; the measured number falls inside the stated range.
By their numbers in this assay, from the lowest: compound 1; then compounds 3 and 2 (each within the scatter of the next).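

In this assay, the first step readable at this position puts 4-chlorophenyl in place of 2-(trifluoromethyl)phenyl on a double-bonded chain carbon bound to a double-bonded chain carbon and gives a 1.1-fold lower number from compound 2 to compound 3 (0.06 log units; within the scatter) for this exchange. Here, a change from three fluorine atoms to one chlorine atom, with the aromatic ring kept, leaves the read-out within the scatter. No measurement at hand accounts for this outcome.

The step replaces the whole aryl group, so the contributions of the chlorine and the trifluoromethyl cannot be read apart. Going by these compounds, whether an amine on the aromatic ring, or a carboxylic acid in place of the ring, would move the number beyond the scatter remains open.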